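The compounds below may be only part of what the source reports. "The series", "measured", "known", "first", "only" and "open" are said of these compounds alone.

Measured so far in an ADME assay on Huh-7 cells (Homo sapiens) for cytotoxicity; a higher number here means that more compound is tolerated, a lower number that less compound is tolerated:

compound 1 `CN1CCN(CCNCc2cn(-c3ccc(F)cc3F)nc2-c2ccccc2)CC1`: > 20000 nM
compound 2 `CCCN1CCC(CNCc2cn(-c3ccc([N+](=O)[O-])cc3)nc2-c2ccc(C(F)(F)F)cc2)CC1`: 2300 nM

Of the compounds shown here, two sharing the same core have been measured in this assay, and they do not give the same kind of result. For compound 1 the reading is a limit of the assay rather than a number: compound 1 gives > 20000 nM in this assay, which is the limit of > 20000 nM in this assay, at which 1 of the 2 values shown sits. Compound 2, by contrast, gives a definite value of 2300 nM in this assay. Between these two no single-change step can be drawn, since they differ at several places at once, so their two values only show that one compound is tolerated up to the limit while the other is not.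

Compound 3 `CN1CCN(CCNCc2cn(-c3ccc(F)cc3F)nc2-c2ccccc2Cl)CC1` has not yet been measured. It differs from compound 1 in one place only: chloro in place of hydrogen on an aromatic carbon. A small change of this kind on the shared core gives no reason from the measured compounds to expect a shift; the step of a number no higher from compound 1 to compound 3 (the limit leaves the size open) is expected to stay within the usual scatter, in part because compound 1 itself sits at the limit of > 20000 nM in this assay, at which 1 of the 2 values shown sits. Compound 3 is therefore estimated at 20000 nM, within a range from 8000 nM to 50000 nM.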

Compound 3, half-maximal cytotoxic concentration: > 20000 nM
Compound 3: only a limit was reported (the forecaster's own chance of this, stated with the estimate: 60%); the middle value sits exactly at the limit.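

In this assay compound 3 gives > 20000 nM, which is a limit of the assay. Compound 1 also gives a limit, > 20000 nM, so no step can be read between compound 1 and compound 3. The compounds shown leave open whether chloro in place of hydrogen on an aromatic carbon changes how much compound is tolerated.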